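Exposure notes: methyl for fluoro on the fused ring

The source may report more compounds than this note shows. Statements on the series, on what has been measured and on what is new or still open speak of the compounds shown alone.

The series is read in an ADME assay on the whole organism (Rattus norvegicus, strain Sprague-Dawley) for pharmacokinetics, read by LC-MS, with a stated time of 6 h, at a dose of 30 mg/kg by the oral route; on this read-out higher numbers stand for higher exposure at the dose given and lower numbers for lower exposure. Compound 1 `COc1ccc(Oc2ccc(N3CC(=O)N([C@@H](CC4CCN(C(=O)C(C)C)CC4)c4nc5ccc(C)cc5n4C)C3=O)cc2)cc1` gives 774 nM in this assay. Compound 2 `CC(C)C(=O)N1CCC(C[C@@H](c2nc3ccc(F)cc3n2C2CC2)N2C(=O)CN(c3ccc(Oc4ccc(F)cc4)cc3)C2=O)CC1` gives 4440 nM in this assay, the higher of the two numbers recorded so far, and its gap to compound 1 lies beyond the scatter; the two compounds differ in several places, so only the two values themselves are compared here. Compound 3 `Cc1ccc2nc([C@H](CC3CCN(C(=O)C(C)C)CC3)N3C(=O)CN(c4ccc(Oc5ccc(F)cc5)cc4)C3=O)n(C3CC3)c2c1` is not yet measured. It differs from compound 2 in one place: methyl in place of fluoro on an aromatic carbon. Among the compounds with values here, no step between measured compounds isolates this change, and compound 1, which also carries methyl on its fused ring, differs from compound 2 elsewhere as well. The expected step is modest, a 1.5-fold lower number from compound 2 to compound 3 (0.17 log units; within the scatter), within the scatter and slightly downward. Compound 3 is expected to give 3000 nM in this assay, with a range from 1200 nM to 7500 nM.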

Compound 3, maximal plasma concentration: 1270 nM
Estimate against measurement, compound 3: 2.4-fold (0.37 log units) above; measured number inside the range.
By their numbers in this assay, from the lowest: compounds 1 and 3 (each within the scatter of the next); then compound 2.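

Methyl in place of fluoro on this aromatic carbon gives a 3.5-fold lower number from compound 2 to compound 3 (0.54 log units; beyond the scatter) in this assay and is the only change isolated so far, whereas the gap between the two earlier compounds could not be assigned to any one place. The read-out therefore responds to this position on its own. It does so although the heavy-atom count, hydrogen-bond donors, hydrogen-bond acceptors and net charge are the same on both sides of the exchange. No measurement shown here accounts for the step.

As far as these compounds go, whether a chloro, methoxy or nitrile group on this aromatic carbon would sit closer to fluoro or to methyl remains open. Also open, from the compounds shown here alone, is whether the same exchange gives a step of similar size on the core of compound 1, which differs from compound 2 in other places as well.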